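From a hydroxy chain to a carboxy group

The source may report more compounds than this note shows. Statements on the series, on what has been measured and on what is new or still open speak of the compounds shown alone.

- compound 1 (`CCn1c(C(=O)NCCO)ccc1C(CC)(CC)c1ccc(OCS(=O)(=O)c2ccccc2)c(C)c1`): 19900 nM
- compound 2 (`CCn1c(C(=O)NC2(CO)CC2)ccc1C(CC)(CC)c1ccc(OCS(=O)(=O)c2ccccc2)c(C)c1`): 45400 nM
- compound 3 (`CCn1c(C(=O)NCCCO)ccc1C(CC)(CC)c1ccc(OCS(=O)(=O)c2ccccc2)c(C)c1`): 26600 nM

All three values come from a functional assay on BXPC-3 cells (Homo sapiens) for antiproliferative activity, read by MTT assay, with a stated time of 24 h; a lower number here means a stronger inhibitor, a higher number a weaker inhibitor. The value of compound 3 (26600 nM) lies within the scatter of both other compounds, so it stands level with them on these numbers. Compound 4 (`CCn1c(C(=O)NCC(=O)O)ccc1C(CC)(CC)c1ccc(OCS(=O)(=O)c2ccccc2)c(C)c1`) has not yet been measured. It differs from compound 3 by carboxy in place of 2-hydroxyethyl on a saturated chain carbon bound to an amide-type nitrogen. The measured steps all change the group on that nitrogen, and they are small: a 1.3-fold higher number from compound 1 to compound 3 (0.13 log units; within the scatter), a 1.7-fold lower number from compound 2 to compound 3 (0.23 log units; within the scatter), and the only one beyond the scatter, a 2.3-fold higher number from compound 1 to compound 2 (0.36 log units; beyond the scatter). None of them introduces a carboxy group, so they bear on this change only indirectly. A modest move is therefore expected, with a tentative lean upward, and the expected step is a 1.4-fold higher number from compound 3 to compound 4 (0.15 log units; within the scatter). For compound 4 the estimated value is 38000 nM, with an expected range from 16000 nM to 90000 nM.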

Compound 4, half-maximal inhibitory concentration: > 50000 nM
Compound 4: a limit, no number; the forecaster's own chance of this, stated with the estimate: 15%; middle value at least 1.3-fold (0.11 log units) away from the limit.
By their numbers in this assay, from the lowest: compounds 1, 3 and 2 (each within the scatter of the next, the first and the last beyond it). At a limit, above all of these: compound 4.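

For the compounds shown here, compound 4 is the only one of the four compounds that stands at a limit of the assay, not at a number: the limit of > 50000 nM in this assay, at which 1 of the 4 values shown sits. Taken as floors, the steps are an at least 1.8-fold higher number from compound 3 to compound 4 (0.27 log units; that floor lies within the scatter), an at least 1.1-fold higher number from compound 2 to compound 4 (0.04 log units; that floor lies within the scatter) and an at least 2.5-fold higher number from compound 1 to compound 4 (0.40 log units; beyond the scatter), and only the last floor clears the scatter. So a carboxy group on the saturated chain carbon bound to an amide-type nitrogen gives a weaker inhibitor than compound 1 and no sign of a stronger one than compound 2 or compound 3, something the hydroxy-ended chains could not show.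

From the compounds shown here alone, how far the true value of compound 4 lies past its limit stays open. Also open, going by these compounds, is whether an amine or a methyl ester at this chain end, or a carboxy group on a longer chain, would behave the same way.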